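The source may hold more compounds than are shown below. What is called first, only, known or untested is meant among the compounds shown, and "the series" means these compounds.

Working notes on the series. Compound 1 `C=CC(=O)Oc1cc(C(F)(F)F)cc(C(F)(F)F)c1` carries a (vinylcarbonyl)oxy group on the shared core; in an ADME assay for pharmacokinetics, read by LC-MS, in phosphate buffer, with a stated time of 72 h, at pH 7.4, tested at 250 uM (on this read-out lower numbers stand for a shorter-lived compound and higher numbers for a longer-lived compound), compound 1 gives < 0.017 h, which is a limit of the assay and not a number. Compound 2 `C=CS(=O)(=O)c1cc(C(F)(F)F)cc(C(F)(F)F)c1` holds a vinylsulfonyl group in its place; in this assay compound 2 gives < 0.017 h, again a limit of the assay. Among the measured compounds shown here, the step that the two limits leave unreadable from compound 1 to compound 2 therefore cannot be read for size, and the only evidence on the measured values is the limit of < 0.017 h in this assay, at which 2 of the 2 values shown sit.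

Compound 3 `O=C1C=CC(=O)N1c1cc(C(F)(F)F)cc(C(F)(F)F)c1` differs from compound 2 by a group of 7 heavy atoms (4 carbon, 1 nitrogen, 2 oxygen; one five-membered non-aromatic ring with 1 hetero atom) in place of a group of 5 heavy atoms (2 carbon, 2 oxygen, 1 sulfur; no ring), on an aromatic carbon. For the measured compounds named here, no measured step bears on this change, so there is nothing in the numbers that points to a longer-lived compound. The expectation is that the step that the limit leaves unreadable from compound 2 to compound 3 stays within scatter of the limit. Compound 3 is thus estimated at 0.01 h, with a range from 0.003 h to 0.05 h.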

Compound 3, half-life: < 0.017 h
Compound 3: a limit, no number; the forecaster's own chance of this, stated with the estimate: 75%; the middle value is on the limit's open side.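

In this assay compound 3 gives < 0.017 h, a limit of the assay and not a number, so no step among compound 1, compound 2 and compound 3 can be read: the limit of < 0.017 h in this assay, at which 3 of the 3 values shown sit.

The compounds shown leave open how these three rank and whether any group on the shared core gives a half-life readable as a number.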